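Cytotoxicity notes: the step from compound 3 to compound 4

The source may report more compounds than this note shows. Statements on the series, on what has been measured and on what is new or still open speak of the compounds shown alone.

In an ADME assay on HepG2 2.2.15 cells (Homo sapiens) for cytotoxicity, read by MTT assay (on this read-out lower numbers stand for higher toxicity in this test and higher numbers for lower toxicity in this test), compound 1 (`COc1ccc(/C=C/C(=O)Oc2ccc(C(C)=O)cc2)cc1`) gives > 3270000 nM as a limit of the assay and not a number. Compound 2 (`CC(=O)c1ccc(OC(=O)c2ccco2)cc1`) gives > 4040000 nM in this assay as a limit too. Compound 3 (`CC(=O)c1ccc(O[C@@H]2O[C@H](COC(=O)/C=C/c3cccc(F)c3)[C@@H](O)[C@H](O)[C@H]2O)cc1`) gives 828000 nM in this assay and is the only one of the three with an actual number. Compound 4 (`CC(=O)c1ccc(O[C@@H]2O[C@H](COC(=O)c3ccccc3)[C@@H](O)[C@H](O)[C@H]2O)cc1`) keeps the core of compound 3 but has phenyl in place of 2-(3-fluorophenyl)ethenyl on a carbonyl carbon. Within the data shown here, no measured pair shows the size of such a change. Among the measured compounds shown here, the estimated step of a 1.8-fold higher number from compound 3 to compound 4 (0.26 log units; within the scatter) in this assay is expected to be modest and towards lower toxicity in this test, resting on compound 3 at 828000 nM as the only number available. This expectation is weakly supported, and a step within the scatter would not surprise. For compound 4 the estimate is 1500000 nM with 550000 nM to 4000000 nM as the expected range.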

Compound 4, half-maximal cytotoxic concentration: 1050000 nM
Compound 4: middle estimate off by 1.4-fold (0.15 log units), on the high side, and the stated range covers the measured number.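

The first pair differing in one place shows that phenyl in place of 2-(3-fluorophenyl)ethenyl on a carbonyl carbon gives a 1.3-fold higher number from compound 3 to compound 4 (0.10 log units; within the scatter) in this assay. Here, 9 heavy atoms give way to 6 and the double bond outside aromatic rings leaves, yet the read-out stays within the scatter, so this pair shows no sensitivity to this particular change. Nothing shown gives a cause for this step.

As far as these compounds go, the fluorine and the double bond leave together, so their separate contributions stay open. Also open, from the compounds shown here alone, is what a carboxylic acid, an amine or a longer chain would give on this carbonyl carbon.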